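Trimming the naphthalene amide of compound 1 to a bare amine

The source may report more compounds than this note shows. Statements on the series, on what has been measured and on what is new or still open speak of the compounds shown alone.

Compound 1 `CCOC(=O)N1CCC(NS(=O)(=O)c2ccc(C(=O)NC3CCCCC3)c3ccccc23)CC1` is one of three close analogues measured in an assay on L1.2 cells for binding affinity to C-C chemokine receptor type 8 (Homo sapiens) (on this read-out higher numbers stand for weaker inhibition and lower numbers for stronger inhibition), in which compound 1 gives 9.5 nM. Compound 2 `CCC(=O)N1CCC(NS(=O)(=O)c2ccc(NC(=O)c3ccccc3C)c3ccccc23)CC1` gives 2.5 nM in this assay, and compound 3 `Cc1ccccc1C(=O)Nc1ccc(S(=O)(=O)NC2CCN(C(=O)C3CCCC3)CC2)c2ccccc12` gives 9.1 nM. Among the three, compound 1 stands at the highest number; compound 3 sits within the scatter of it, while compound 2 sits beyond the scatter at a lower number. Among the measured compounds shown here, the one step between measured compounds that differ in a single place, a 3.6-fold higher number from compound 2 to compound 3 (0.56 log units; beyond the scatter), concerns the acyl group on the piperidine nitrogen and not the substituent on the naphthalene ring.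

Compound 4 `CCOC(=O)N1CCC(NS(=O)(=O)c2ccc(N)c3ccccc23)CC1` differs from compound 1 by amino in place of cyclohexylcarbamoyl on an aromatic carbon. For the measured compounds named here, no measured step touches that position, so nothing measured bears directly on this change. What remains is the observation that every measured compound carries a sizeable group there, and compound 4 loses all of it. The step from compound 1 to compound 4 in this assay is therefore expected to be a clear rise in the number, a 16-fold higher number from compound 1 to compound 4 (1.20 log units; beyond the scatter), though with wide uncertainty. Compound 4 is thus expected to give about 150 nM in this assay, estimated to fall between 25 nM and 900 nM.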

Compound 4, inhibition constant: > 5000 nM
Compound 4: only a limit was reported; the forecaster's own chance of this, stated with the estimate: 10%; middle value at least 33-fold (1.52 log units) from the limit.
By their numbers in this assay, from the lowest: compound 2; then compounds 3 and 1 (each within the scatter of the next). At a limit, above all of these: compound 4.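

With amino in place of cyclohexylcarbamoyl on an aromatic carbon, the step is large and beyond the scatter, an at least 520-fold higher number from compound 1 to compound 4 (2.72 log units; beyond the scatter), which shows that in this assay this position is not indifferent to the change on the core of compound 1. Under HOW the two groups count, the hydrogen-bond donor and acceptor tallies are the same, so the step goes with a change in which the six-membered non-aromatic ring and the double bond leave while those tallies stay as they were, though this single pair cannot separate the two parts that leave. The reading for compound 4 is a limit and not a number: the limit of > 5000 nM in this assay, at which 1 of the 4 values shown sits.

The compounds shown leave open how much of cyclohexylcarbamoyl is needed, as nothing here stands between it and amino at this place, such as a plain carboxamide, a cyclopropyl amide or an acetamide. Also open, going by these compounds, is whether the same change would give a similar step on the propanoyl or cyclopentanecarbonyl piperidines of compound 2 and compound 3, which carry a different amide at this place.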